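Aryl-triazole variation in an antiproliferation series, compound 3 pending

The compounds below may be only part of what the source reports. "The series", "measured", "known", "first", "only" and "open" are said of these compounds alone.

Measured so far:
- compound 1, `N#CC1=C(N)Oc2c(c3nc4ccccc4nc3c3ccccc23)C12C(=O)N(Cc1cnnn1-c1ccc(Cl)c(Cl)c1)c1ccccc12`: > 50000 nM
- compound 2, `N#CC1=C(N)Oc2c(N)cc3nc4ccccc4nc3c2C12C(=O)N(Cc1cnnn1-c1cccc(Br)c1)c1ccccc12`: > 50000 nM

In an ADME assay on L02 cells (Homo sapiens) for antiproliferative activity, read by MTT assay, with a stated time of 48 h (on this read-out lower numbers stand for stronger inhibition and higher numbers for weaker inhibition), compound 1 gives > 50000 nM, which is a limit of the assay and not a number. In this assay compound 2 likewise gives > 50000 nM, again a limit. Within the data shown here, both readings therefore stand at the limit of > 50000 nM in this assay, at which 2 of the 2 values shown sit, and nothing further can be read from the pair: no step between the two measured compounds can be sized, and neither can be called more or less active than the other.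

Compound 3 is `N#CC1=C(N)Oc2c(N)cc3nc4ccccc4nc3c2C12C(=O)N(Cc1cnnn1-c1c(Cl)cc(Cl)cc1Cl)c1ccccc12`. It differs from compound 2 by 2,4,6-trichlorophenyl in place of 3-bromophenyl on an aromatic nitrogen, the triazole and the rest of the shared core being kept. Among the measured compounds shown here, with compound 2 at a limit in this assay, no measured step offers a direction for this change, and no effect beyond the scatter is expected from it.

The expected step in this assay is a number no higher from compound 2 to compound 3 (the limit leaves the size open), that is, compound 3 is expected to remain at the limit. The estimate for compound 3 in this assay is 50000 nM, with a range from 20000 nM to 100000 nM.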

Compound 3, half-maximal inhibitory concentration: > 50000 nM
Compound 3 ended at the assay's limit; the forecaster's own chance of this, stated with the estimate: 80%; the middle value lies on the limit itself.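

No step from compound 2 to compound 3 can be read in this assay, because both compounds stand at a limit of the assay and not at a number: the limit of > 50000 nM in this assay, at which 3 of the 3 values shown sit.

The compounds shown leave open how 2,4,6-trichlorophenyl and 3-bromophenyl compare on this read-out, and whether any variation of this series gives a measurable value on these cells.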